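The source may report more compounds than this note shows. Statements on the series, on what has been measured and on what is new or still open speak of the compounds shown alone.

Measured compounds:
compound 1, `CC(C)c1n[nH]c2c(NCc3ccc(-c4ccccn4)cc3)nc(SCCC(N)=O)nc12`: 120 nM in a functional assay on HT cells (Homo sapiens) for antiproliferative activity, read by fluorescence, with a stated time of 72 h; a lower number here means a stronger inhibitor of growth, a higher number a weaker inhibitor of growth
compound 2, `CCC(O)CSc1nc(NCc2ccc(-c3ccccn3)cc2)c2[nH]nc(C(C)C)c2n1`: 273 nM
compound 3, `CC(C)c1n[nH]c2c(NCc3ccc(-c4ccccn4)cc3)nc(SCCO)nc12`: 48 nM

Compound 3 stands lowest of the three, with its steps to compound 1 and compound 2 both beyond the scatter. Compound 4, `CC(C)c1n[nH]c2c(NCc3ccc(-c4ccccn4)cc3)nc(SCCNC(N)=O)nc12`, differs from it by ureido in place of hydroxy on a saturated chain carbon, two bonds along the chain from a sulfur. For the measured compounds named here, the one measured step that bears on this is a 2.5-fold lower number from compound 1 to compound 3 (0.40 log units; beyond the scatter), where the hydroxy took the place of the carbamoyl that compound 1 carries; compound 4 goes back toward a group resembling that carbamoyl. A modest rise is therefore expected, roughly undoing that step, as a 2.3-fold higher number from compound 3 to compound 4 (0.36 log units; beyond the scatter). For compound 4 the estimate in this assay is 110 nM, with a range from 50 nM to 250 nM.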

Compound 4, concentration for 50% growth inhibition: 240 nM
Beside the measured number, compound 4's estimate is 2.2-fold (0.34 log units) below it, and the stated range covers the measured number.
By their numbers in this assay, from the lowest: compound 3; then compounds 1, 4 and 2 (each within the scatter of the next, the first and the last beyond it).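

At this place, two bonds along the chain from a sulfur, ureido does not match hydroxy in this assay (a 5.0-fold higher number from compound 3 to compound 4 (0.70 log units; beyond the scatter)). Beside the carbamoyl of compound 1, ureido gives a step inside the scatter (a 2.0-fold higher number from compound 1 to compound 4 (0.30 log units; within the scatter)), and the same holds beside the 1-hydroxypropyl of compound 2 (a 1.1-fold lower number from compound 2 to compound 4 (0.06 log units; within the scatter)). Nothing available explains these differences.

On these data alone, it remains open whether the low number depends on hydroxy specifically. An amine or a carboxylic acid on the same chain, or hydroxy on a longer chain, would help to answer that.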